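Halogen swap on the shared core: bromo to chloro

The source may hold more compounds than are shown below. What is called first, only, known or untested is meant among the compounds shown, and "the series" means these compounds.

Compound 1 `CCN(CC)CN1C(=O)/C(=N\c2nc3ccc(C)cc3s2)c2c(Br)cccc21` and compound 2 `Cc1ccc2nc(/N=C3\C(=O)N(CN4CCCCC4)c4cccc(Br)c43)sc2c1` share the same core and differ only at the amine on the saturated chain carbon bound to the amide-type nitrogen in a ring. In a functional assay on MDA-MB-231 cells (Homo sapiens) for cytotoxicity, read by sulforhodamine B assay, with a stated time of 48 h (a higher number here means a weaker inhibitor of growth, a lower number a stronger inhibitor of growth), compound 1 gives 28700 nM; in this assay compound 2 gives 38300 nM. Within the data shown here, the two numbers lie within the scatter of each other, and the single measured step, a 1.3-fold higher number from compound 1 to compound 2 (0.13 log units; within the scatter), does not reach beyond the scatter. Compound 3 `Cc1ccc2nc(/N=C3\C(=O)N(CN4CCCCC4)c4cccc(Cl)c43)sc2c1` keeps the piperidin-1-yl of compound 2 and changes only the halogen: chloro in place of bromo on an aromatic carbon. Among the measured compounds shown here, no measured step touches this halogen position, so nothing points toward a change in either direction, and the expectation rests on compound 2 alone at 38300 nM. Compound 3 is expected to give 38000 nM in this assay, with a range of 15000 nM to 100000 nM, which means an expected step of a 1.0-fold lower number from compound 2 to compound 3 (0.00 log units; within the scatter).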

Compound 3, concentration for 50% growth inhibition: 55800 nM
Compound 3: middle estimate off by 1.5-fold (0.17 log units), on the low side; measured number inside the range.
By their numbers in this assay, from the lowest: compounds 1, 2 and 3 (each within the scatter of the next).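

In this assay the halogen position now has its first measured step, a 1.5-fold higher number from compound 2 to compound 3 (0.16 log units; within the scatter), with the piperidin-1-yl held fixed. Compound 1 and compound 2 spoke only to the amine on the chain carbon, whereas this pair shows that chloro in place of bromo on this aromatic carbon also stays within the scatter, a statement limited to these two halogens on this one background. Nothing at hand bears on the reason for the size of this step.

The compounds shown carry only bromo and chloro here, so it stays open how fluoro, a methoxy group or plain hydrogen at this position would read. Also open, as far as these compounds go, is whether the halogen swap reads the same with diethylamino, or with a morpholine, on the chain carbon.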